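Replacing morpholine with trimethoxyphenyl on the aminopyridine nitrogen

The source may hold more compounds than are shown below. What is called first, only, known or untested is meant among the compounds shown, and "the series" means these compounds.

Compound 1 `COc1cccc(CNC(=O)c2cccc(C(C)Oc3ccnc(Nc4cnn(C)c4)c3)c2)c1` gives > 100000 nM in a functional assay on NCI-H3122 cells (Homo sapiens) for antiproliferative activity, read by MTT assay, with a stated time of 48 h; on this read-out lower numbers stand for stronger inhibition and higher numbers for weaker inhibition.
Compound 2 `CC(Oc1ccnc(Nc2cnn(C)c2)c1)c1cccc(C(=O)NCc2ccc(C#N)cc2)c1` gives 35100 nM in this assay.
Compound 3 `Cc1ccc(CNC(=O)c2cccc(C(C)Oc3ccnc(NN4CCOCC4)c3)c2)cc1` gives > 100000 nM in this assay.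

For compound 3 the figure is only a limit of the assay, not a measured number: it sits at the limit of > 100000 nM in this assay, at which 2 of the 3 values shown sit. Compound 4 `COc1cc(Nc2cc(OC(C)c3cccc(C(=O)NCc4ccc(C)cc4)c3)ccn2)cc(OC)c1OC` differs from compound 3 in one place: 3,4,5-trimethoxyphenyl in place of morpholin-4-yl on a nitrogen on an aromatic ring. For the measured compounds named here, the single measured step, an at least 2.8-fold lower number from compound 1 to compound 2 (0.45 log units; beyond the scatter), concerns the group on the amide side and therefore bears on nothing at this nitrogen. Going by the values given here, with no step to lean on, the expectation for compound 4 is a measurable number rather than a limit, though not a small one. Compound 4 is expected to give 20000 nM, within a range from 2000 nM to 100000 nM. That estimate means a step of an at least 5.0-fold lower number from compound 3 to compound 4 (0.69 log units; beyond the scatter) is expected.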

Compound 4, half-maximal inhibitory concentration: 7800 nM
Compound 4: middle estimate off by 2.6-fold (0.41 log units), on the high side; the measured number falls inside the stated range.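

In this assay, the group on this nitrogen clearly matters: 3,4,5-trimethoxyphenyl in place of morpholin-4-yl gives an at least 12-fold lower number from compound 3 to compound 4 (1.10 log units; beyond the scatter). This is the first step shown at this nitrogen, and it brings a measured number where there was only a limit. Its true size stays unknown, since compound 3 is a limit and not a number: the limit of > 100000 nM in this assay, at which 2 of the 4 values shown sit.

On these data alone, whether a plain phenyl ring without methoxy groups would do as well remains open. So does whether 3,4,5-trimethoxyphenyl and the 4-cyanophenyl on the amide side would add up.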